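Predicting Cytotoxicity After an Aryl Group Exchange

The source may hold more compounds than are shown below. What is called first, only, known or untested is meant among the compounds shown, and "the series" means these compounds.

Compound 2 `COc1ccc(/C=N/NC(=O)Nc2ccc(Oc3ccnc4cc(OCCCN5CCCCC5)c(OC)cc34)c(F)c2)cc1` was tested in a functional assay on HT-29 cells (Homo sapiens) for cytotoxicity, read by MTT assay, with a stated time of 72 h (a higher number here means a weaker inhibitor, a lower number a stronger inhibitor), where compound 2 gives 590 nM. Its only measured companion, compound 1 `COc1cc2c(Oc3ccc(NC(=O)N/N=C/c4ccc([N+](=O)[O-])cc4)cc3F)ccnc2cc1OCCCN1CCCC1`, gives 310 nM in this assay; the two values lie within the usual scatter of each other, so neither can be called the stronger. Compound 3 `COc1cc2c(Oc3ccc(NC(=O)N/N=C/c4ccc(F)cc4Cl)cc3F)ccnc2cc1OCCCN1CCCCC1` has not been measured; it differs from compound 2 in one place: 2-chloro-4-fluorophenyl in place of 4-methoxyphenyl on a carbon with a double bond to nitrogen. Going by the values given here, no measured pair isolates such a change, so the expected step of a 1.3-fold lower number from compound 2 to compound 3 (0.12 log units; within the scatter) is small, of uncertain direction, and not clearly beyond the scatter. Compound 3 is therefore expected to give about 450 nM in this assay, within 150 nM to 1300 nM.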

Compound 3, half-maximal inhibitory concentration: 260 nM
Beside the measured number, compound 3's estimate is 1.7-fold (0.24 log units) above it; low and high end bracket the measured number.
By their numbers in this assay, from the lowest: compounds 3, 1 and 2 (each within the scatter of the next, the first and the last beyond it).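

Exchanging the aryl group on the carbon with a double bond to nitrogen registers in this assay: 2-chloro-4-fluorophenyl in place of 4-methoxyphenyl gives a 2.3-fold lower number from compound 2 to compound 3 (0.36 log units; beyond the scatter) and so a modest but real gain. Going by these compounds alone, this is the first single-place comparison available, and it shows that this position can move the number beyond the scatter. Nothing measured here bears on why the number moves.

As far as these compounds go, whether the chlorine or the fluorine alone would give this step stays open. So does the reading for a plain phenyl or an aminophenyl group at this place.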